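The source may hold more compounds than are shown below. What is called first, only, known or untested is meant among the compounds shown, and "the series" means these compounds.

Measured so far:
compound 1, `O=C(NCc1ccc(-c2noc(CCC3CC3)n2)cc1)[C@H]1NCC[C@@H]1O`: 5000 nM
compound 2, `CCCCCCCc1cc(-c2ccc(CNC(=O)[C@H]3NCC[C@@H]3O)cc2)n[nH]1`: 1100 nM

Both were tested in an assay on isolated protein for inhibition of sphingosine kinase 1 (Homo sapiens); on this read-out higher numbers stand for weaker inhibition and lower numbers for stronger inhibition. Compound 1 gives the higher of the two numbers, so it inhibits more weakly than compound 2, and the gap between them lies beyond the usual scatter of this assay. Compound 3, `O=C(NCc1ccc(-c2noc(C3CCCCCC3)n2)cc1)[C@H]1NCC[C@@H]1O`, has not been measured. It differs from compound 1 in one place: cycloheptyl in place of 2-cyclopropylethyl on an aromatic carbon. Among the measured compounds shown here, no measured pair shows this change directly, so its size in this assay is a judgement. For compound 3 a modest gain in inhibition is expected, a 3.3-fold lower number from compound 1 to compound 3 (0.52 log units; beyond the scatter). Compound 3 is estimated at 1500 nM, in a range from 400 nM to 6000 nM.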

Compound 3, half-maximal inhibitory concentration: 620 nM
Beside the measured number, compound 3's estimate is 2.4-fold (0.38 log units) above it; low and high end bracket the measured number.
By their numbers in this assay, from the lowest: compounds 3 and 2 (each within the scatter of the next); then compound 1.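

On this aromatic carbon of the five-membered ring, the group's shape and size clearly matter: in this assay, cycloheptyl in place of 2-cyclopropylethyl gives an 8.1-fold lower number from compound 1 to compound 3 (0.91 log units; beyond the scatter). Both groups are carbon only, with no hydrogen-bond donors or acceptors, so this gain needs neither. No measurement here gives a reason for it. Still open, from the compounds shown here alone, is whether the seven-membered ring itself matters or simply the larger carbon count. A cyclohexyl or cyclopentyl group at this position would help to separate the two.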